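The compounds below may be only part of what the source reports. "The series", "measured", "known", "first", "only" and "open" are said of these compounds alone.

The compounds measured so far:

Compound 1, `COc1cc2c(cc1C)NC(=O)/C2=C/c1c(Cl)n(C)c2cc(C)c(OC)cc12`, gives 87100 nM in a functional assay on cells (Cancer cell lines, Homo sapiens) for inhibition, with a stated time of 48 h; on this read-out lower numbers stand for stronger inhibition of growth and higher numbers for weaker inhibition of growth.
Compound 2, `COc1cc2c(cc1C)N(C)C(=O)/C2=C/c1c(Cl)n(C)c2cc(C)c(OC)cc12`, gives 26900 nM in this assay.
Compound 3, `CN(C)c1ccc2[nH]c(Cl)c(/C=C3/C(=O)Nc4ccc(O)cc43)c2c1`, gives 36300 nM in this assay.

Compound 1 and compound 2 share one core and differ in a single place: methyl in place of hydrogen on an amide-type nitrogen in a ring. That change brought a 3.2-fold lower number from compound 1 to compound 2 (0.51 log units; beyond the scatter). Compound 3 is built on a different core; the difference between the two cores is not broken down here. Its number lies close to that of compound 2, and it is lower than that of compound 1.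

Compound 4, `CN(C)c1ccc2[nH]c(Cl)c(/C=C3/C(=O)N(C)c4ccc(O)cc43)c2c1`, has not yet been measured. It differs from compound 3 by methyl in place of hydrogen on an amide-type nitrogen in a ring, which is the same change that turns compound 1 into compound 2. In this assay, going by the values given here, a step of about the same size is expected from compound 3 to compound 4, namely a 2.8-fold lower number from compound 3 to compound 4 (0.45 log units; beyond the scatter), because the only earlier example of this change gave a 3.2-fold lower number from compound 1 to compound 2 (0.51 log units; beyond the scatter). Since that expectation rests on one pair of compounds on a different core, it is held loosely. For compound 4 the estimated value is 13000 nM, with a likely range from 5000 nM to 35000 nM.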

Compound 4, concentration for total growth inhibition: 33900 nM
Compound 4: the middle estimate sits 2.6-fold (0.42 log units) below what was measured; the measured number falls inside the stated range.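

In this assay, putting methyl in place of hydrogen on an amide-type nitrogen in a ring gave a 1.1-fold lower number from compound 3 to compound 4 (0.03 log units; within the scatter), a step too small to separate from repeat measurement. The change therefore did not bring the same step on the two cores, so the step seen on the core of compound 1 cannot simply be transferred to the core of compound 3: the same change on two cores in this assay, a 3.2-fold lower number (0.51 log units; beyond the scatter) from compound 1 to compound 2 and a 1.1-fold lower number (0.03 log units; within the scatter) from compound 3 to compound 4, 3.0-fold (0.48 log units) apart, beyond the scatter of two such steps. Going by these compounds alone, this does not show why the two steps differ, since the two cores differ in more than one place and each core supplies only one pair of compounds, and it gives no rule for how the same change would behave on any further core.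

The compounds shown leave open which difference between the two cores goes with the difference in steps. They also leave open whether ethyl, a longer chain or a chain ending in an amine on that same nitrogen would give different steps on the two cores.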